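The source may report more compounds than this note shows. Statements on the series, on what has been measured and on what is new or still open speak of the compounds shown alone.

Three compounds built on one shared core were tested in a functional assay on SK-BR-3 cells (Homo sapiens) for antiproliferative activity, read by XTT assay, with a stated time of 72 h; on this read-out higher numbers stand for weaker inhibition and lower numbers for stronger inhibition. Compound 1 `COc1ccc(-c2cc3ccccc3nc2/C=C/C(=O)c2ccc(OC)cc2OC)cc1` gives 2260 nM, compound 2 `COc1ccc(-c2cc3ccccc3nc2/C=C/C(=O)c2c(OC)cccc2OC)cc1` gives 3830 nM, and compound 3 `COc1ccc(-c2cc3ccccc3nc2/C=C/C(=O)c2ccc([N+](=O)[O-])cc2)cc1` gives 590 nM, the lowest of the three numbers. The change between the first two was a 1.7-fold higher number from compound 1 to compound 2 (0.23 log units; within the scatter), whereas a 3.8-fold lower number from compound 1 to compound 3 (0.58 log units; beyond the scatter) and a 6.5-fold lower number from compound 2 to compound 3 (0.81 log units; beyond the scatter) show that exchanging the group on the carbonyl carbon can shift the number beyond the scatter. Compound 4 `COc1ccc(-c2cc3ccccc3nc2/C=C/C(=O)c2c[nH]c3ccccc23)cc1` makes another exchange at that position: 1H-indol-3-yl in place of 4-nitrophenyl on a carbonyl carbon. For the measured compounds named here, no measured step involves a 1H-indol-3-yl group, so the direction is open; a modest shift is expected, a 2.0-fold higher number from compound 3 to compound 4 (0.31 log units; beyond the scatter). Compound 4 is estimated at 1200 nM, within a range from 300 nM to 5000 nM.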

Compound 4, half-maximal inhibitory concentration: 3450 nM
The estimate for compound 4 lay 2.9-fold (0.46 log units) below the measured number; measured number inside the range.
By their numbers in this assay, from the lowest: compound 3; then compounds 1, 4 and 2 (each within the scatter of the next).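

In this assay the 1H-indol-3-yl group on the carbonyl carbon does not share the low number of the 4-nitrophenyl group, with a 5.8-fold higher number from compound 3 to compound 4 (0.77 log units; beyond the scatter) beyond the scatter. It instead sits level with both dimethoxyphenyl groups, with a 1.1-fold lower number from compound 2 to compound 4 (0.05 log units; within the scatter) and a 1.5-fold higher number from compound 1 to compound 4 (0.18 log units; within the scatter) both within the scatter, so among these four groups only compound 3 stands apart. Nothing measured here accounts for that difference. From the compounds shown here alone, whether the low number of compound 3 is tied to the nitro group itself stays open, and so does what an amine or a carboxylic acid in its place would give.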